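Side-chain change on the compound 3 acid

This account rests on a few compounds, and the source may have more. Where it says the series, first, only, none or still open, it means among the compounds named here.

Measured so far in a functional assay on MDA-MB-435S cells (Homo sapiens) for cytotoxicity, read by MTT assay; a lower number here means a stronger inhibitor, a higher number a weaker inhibitor:
- compound 1 `CCOC(=O)C(C)Oc1c(-c2ccc(OC)cc2)oc2c(CC=C(C)C)c(O)cc(O)c2c1=O`: 4100 nM
- compound 2 `CCOC(=O)C(C)Oc1cc(O)c2c(=O)c(O)c(-c3ccc(OC)cc3)oc2c1CC=C(C)C`: 2500 nM
- compound 3 `COc1ccc(-c2oc3c(CC=C(C)C)c(OC(C)C(=O)O)cc(O)c3c(=O)c2O)cc1`: 5700 nM

Compound 3, at 5700 nM, lies within the scatter of compound 1, at 4100 nM, and these two form the upper end of the three numbers. Compound 2 sits apart from compound 3, with a 2.3-fold higher number from compound 2 to compound 3 (0.36 log units; beyond the scatter).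

The next structure is compound 4 `COc1ccc(-c2oc3c(CC=C(C)C)c(OC/C=C/C(=O)O)cc(O)c3c(=O)c2O)cc1`, which carries 3-carboxyprop-2-en-1-yl in place of 1-carboxyethyl on an oxygen on an aromatic ring. Within the data shown here, no measured pair isolates this change. Among the measured compounds shown here, the only measured step touching this chain is the replacement of ethyl by hydrogen, and it is modest: a 2.3-fold higher number from compound 2 to compound 3 (0.36 log units; beyond the scatter). That step alters the end of the chain and leaves the chain itself in place, so it bears on the present change only indirectly. All three values in this assay also lie close together, which gives no basis for expecting a large move in either direction.

The expected size is a 1.1-fold lower number from compound 3 to compound 4 (0.06 log units; within the scatter), so no step beyond the scatter is anticipated. The estimate for compound 4 is 5000 nM, with an expected range from 2200 nM to 11000 nM.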

Compound 4, half-maximal inhibitory concentration: 11300 nM
Compound 4: middle estimate off by 2.3-fold (0.35 log units), on the low side, outside the stated range (above it).
By their numbers in this assay, from the lowest: compounds 2, 1, 3 and 4 (each within the scatter of the next, the first and the last beyond it).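

In this assay, placing 3-carboxyprop-2-en-1-yl in place of 1-carboxyethyl on an oxygen on an aromatic ring gives a 2.0-fold higher number from compound 3 to compound 4 (0.30 log units; within the scatter) and so stays within the scatter; on this read-out the two carboxy chains, at 5 and 6 heavy atoms, are not separated, although the entering chain adds a double bond outside aromatic rings. The new comparison with the ester is clearer: replacing 1-(ethoxycarbonyl)ethyl with the unsaturated acid chain gives a 4.5-fold higher number from compound 2 to compound 4 (0.66 log units; beyond the scatter) and lies beyond the scatter, so both carboxy compounds now stand apart from compound 2, the other step being a 2.3-fold higher number from compound 2 to compound 3 (0.36 log units; beyond the scatter) in this series. Nothing measured on these compounds accounts for the numbers, and no explanation for either step can be offered from the data at hand.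

The compounds shown leave open whether the double bond or the chain length carries any weight, a question that a saturated 3-carboxypropyl chain on the same oxygen would address. They also leave open whether the step away from compound 2 depends on the free carboxylic acid, which a primary amide or an amine at the chain end would test.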